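A Longer Carbamoyl Chain on Compound 3

The source may hold more compounds than are shown below. What is called first, only, known or untested is meant among the compounds shown, and "the series" means these compounds.

Compound 1 `CCCCCCCCN(C)C(=O)Cn1cc(Cc2cnc(=O)n(C)c2)c(=O)nc1SCc1ccc(F)cc1` gives 55% in a functional assay on a cell-free system (plasma) for inhibition of platelet-activating factor acetylhydrolase (Homo sapiens), tested at 100 nM; a lower number here means less inhibition, a higher number more inhibition at the concentration tested (going by the name of the read-out).
Compound 2 `CCCCCCCCN(C)C(=O)Cn1cc(Cc2cnc(=O)n(CC(=O)O)c2)c(=O)nc1SCc1ccc(F)cc1` gives 56% in this assay.
Compound 3 `CCCCCCCCN(C)C(=O)Cn1cc(Cc2cnc(=O)n(CC(=O)NC)c2)c(=O)nc1SCc1ccc(F)cc1` gives 63% in this assay.

Compound 3 holds the highest of the three numbers, yet the steps of a number 8 percentage points higher from compound 1 to compound 3 (within the scatter) and a number 7 percentage points higher from compound 2 to compound 3 (within the scatter) both lie within the usual scatter, so no ranking among the three can be read from them. The step of a number 1 percentage points higher from compound 1 to compound 2 (within the scatter) is likewise within the scatter.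

The next compound, compound 4 `CCCCCCCCN(C)C(=O)Cn1cc(Cc2cnc(=O)n(CC(=O)NCCC)c2)c(=O)nc1SCc1ccc(F)cc1`, differs from compound 3 by ethyl in place of hydrogen on a saturated chain carbon bound to an amide-type nitrogen. Of the measured steps, the one that touches the same region is a number 7 percentage points higher from compound 2 to compound 3 (within the scatter), which exchanged the group on the carbonyl carbon and stayed within the scatter. The step of a number 8 percentage points higher from compound 1 to compound 3 (within the scatter), which introduced the methylcarbamoyl group, was also within the scatter. For the measured compounds named here, none of the measured steps altered the length of the chain on the amide-type nitrogen, so nothing on hand argues for a move beyond the scatter in either direction. The expected step is therefore no change at the digits printed from compound 3 to compound 4 (within the scatter), nothing beyond the scatter. Compound 4 is expected to give 63% in this assay, with a range from 48% to 76%.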

Compound 4, a percentage reported as inhibition, at one concentration (the size of the read-out at that concentration, not a potency): 42%
The estimate for compound 4 lay 21 percentage points above the measured number; measured number below the stated range.
By their numbers in this assay, from the lowest: compound 4; then compounds 1, 2 and 3 (each within the scatter of the next).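

In this assay, the length of the chain on the amide-type nitrogen proves to matter: going from methylcarbamoyl to propylcarbamoyl gives a number 21 percentage points lower from compound 3 to compound 4 (beyond the scatter) and is the one change at this position shown to move the number beyond the scatter. The earlier changes on the saturated chain carbon bound to an aromatic nitrogen stayed within the scatter, but propylcarbamoyl does not, with a number 13 percentage points lower from compound 1 to compound 4 (beyond the scatter) and, at the carbonyl carbon, a number 14 percentage points lower from compound 2 to compound 4 (beyond the scatter) as well, so this group stands apart from carboxy and methylcarbamoyl and from the hydrogen of compound 1. Nothing measured on hand explains why the longer chain goes with the lower number.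

With only methylamino and propylamino to compare on the amide carbonyl, the compounds shown leave open whether the fall already appears with ethylamino or continues with butylamino or a longer chain. They also leave open whether a branched isopropylamino, a cyclopropylamino or a dimethylamino group at the same carbonyl carbon would follow propylamino or stay with methylamino.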